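Hydroxy for lactam at the piperidine carbon

The source may report more compounds than this note shows. Statements on the series, on what has been measured and on what is new or still open speak of the compounds shown alone.

Compound 3 `Cc1nc(N2CCC(N3CCCC3=O)CC2)nc2ccc(NC(=O)/C=C/c3ccc(Cl)cc3)cc12` gives 20 nM in a functional assay on CHO-K1 cells for antagonist activity at melanin-concentrating hormone receptor 1 (Homo sapiens), read by inositol phosphate accumulation, with stated times of 10 min and 45 min (on this read-out higher numbers stand for weaker inhibition and lower numbers for stronger inhibition), and carries the lowest number of the three measured. The nearest measured number is that of compound 2 `Cc1nc(N2CCC(O)(C3CCC3)CC2)nc2ccc(NC(=O)/C=C/c3ccc(Cl)cc3)cc12`, which gives 54 nM, and the furthest is that of compound 1 `COCCC1(O)CCN(c2nc(C)c3cc(NC(=O)/C=C/c4ccc(Cl)cc4)ccc3n2)CC1`, which gives 220 nM; both gaps to compound 3 lie beyond the scatter.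

Compound 4 `Cc1nc(N2CCC(O)CC2)nc2ccc(NC(=O)/C=C/c3ccc(Cl)cc3)cc12` differs from compound 3 in one place: hydroxy in place of 2-oxopyrrolidin-1-yl on a saturated ring carbon.

Among the measured compounds shown here, no measured step removes a ring from this carbon outright. The one measured step at the same carbon, a 4.1-fold lower number from compound 1 to compound 2 (0.61 log units; beyond the scatter), exchanges one substituent for another while a hydroxy group remains; it shows that the group on this carbon shifts the number by a modest amount, but in which direction a bare hydroxy moves it is not shown. Compounds 1 and 2, which both bear a hydroxy on this carbon together with a second group, sit above compound 3, so a weakening is expected rather than a gain.

For compound 4 a higher number than compound 3 is therefore expected, a step of roughly a 7.5-fold higher number from compound 3 to compound 4 (0.88 log units; beyond the scatter), with the estimate 150 nM and a range from 45 nM to 500 nM.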

Compound 4, half-maximal inhibitory concentration: 73 nM
For compound 4 the middle estimate is 2.1-fold (0.31 log units) above the measured one, and the stated range covers the measured number.
By their numbers in this assay, from the lowest: compound 3; then compounds 2 and 4 (each within the scatter of the next); then compound 1.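

In this assay, the 2-oxopyrrolidin-1-yl group on this saturated ring carbon reads better than hydroxy alone, with a 3.7-fold higher number from compound 3 to compound 4 (0.56 log units; beyond the scatter). Among the compounds shown here, the compound with the bare hydroxy also lets each second group on the hydroxy-bearing carbon be read on its own for the first time: replacing 2-methoxyethyl with hydrogen gives a 3.0-fold lower number from compound 1 to compound 4 (0.48 log units; beyond the scatter), while replacing cyclobutyl with hydrogen gives a 1.4-fold higher number from compound 2 to compound 4 (0.13 log units; within the scatter), so only 2-methoxyethyl separates from hydrogen. No supporting data accompany these steps, and their cause remains unassigned.

As far as these compounds go, it remains open whether the ring or the carbonyl of the 2-oxopyrrolidin-1-yl group carries its step; an open-chain acetamide or a plain pyrrolidine on the same carbon would separate the two. From the compounds shown here alone, it also remains open whether the ether oxygen or the chain length of 2-methoxyethyl sets its step, which a propyl chain on the hydroxy-bearing carbon would help to distinguish.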